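A few compounds are considered here, and "the series" means these few. Any claim that something is new, unique, unknown or untested is made for them only; others in the source may bear on it.

Of the compounds shown here, three have been tested so far in an ADME assay on MT4 cells (Homo sapiens) for cytotoxicity, read by MTT assay; on this read-out higher numbers stand for lower toxicity in this test and lower numbers for higher toxicity in this test. For compound 1 `Cc1ccc(N(C(=O)c2ccccc2C)C(=S)OCCN2C(=O)c3ccccc3C2=O)cc1` the result is a limit and not a number: > 100000 nM. Compound 2 `Cc1ccc(N(C(=O)c2ccccc2[N+](=O)[O-])C(=S)OCCN2C(=O)c3ccccc3C2=O)cc1` gives 100000 nM. Among the compounds with values here, the one measured step, a number no higher from compound 1 to compound 2 (the limit leaves the size open), has no readable size and lies at another place in the molecule. Compound 3 `O=C1c2ccccc2C(=O)N1CCOC(=S)N(C(=O)c1cc(F)ccc1F)c1ccc(Cl)cc1` gives 54000 nM, a value within the usual scatter of that of compound 2.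

Compound 4 `Cc1ccc(N(C(=O)c2cc(F)ccc2F)C(=S)OCCN2C(=O)c3ccccc3C2=O)cc1` differs from compound 3 in a single group: methyl in place of chloro on an aromatic carbon. This is methyl in place of chloro on an aromatic carbon, para to a large group, so 4-chlorophenyl becomes 4-methylphenyl. Within the data shown here, no measured pair shows this exchange on its own. Compound 1 and compound 2 both carry the 4-methylphenyl group, but they also differ from compound 3 elsewhere. Compound 2, at 100000 nM, therefore offers only a loose guide, pointing to a small change toward a higher number. The expected step is a 1.4-fold higher number from compound 3 to compound 4 (0.14 log units; within the scatter), which may well stay inside the scatter. For compound 4 the estimated value is 75000 nM, with an expected range from 40000 nM to 140000 nM.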

Compound 4, half-maximal cytotoxic concentration: 62000 nM
Beside the measured number, compound 4's estimate is 1.2-fold (0.08 log units) above it; the measured number falls inside the stated range.
By their numbers in this assay, from the lowest: compounds 3, 4 and 2 (each within the scatter of the next).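

On the aromatic carbon para to a large group, methyl in place of chloro gives a 1.1-fold higher number from compound 3 to compound 4 (0.06 log units; within the scatter), so on this pair 4-chlorophenyl and 4-methylphenyl cannot be told apart in this assay. On the carbonyl carbon, 2,5-difluorophenyl in place of 2-nitrophenyl gives a 1.6-fold lower number from compound 2 to compound 4 (0.21 log units; within the scatter), which also stays within the scatter, while 2,5-difluorophenyl in place of 2-methylphenyl gives an at least 1.6-fold lower number from compound 1 to compound 4 (0.20 log units; that floor lies within the scatter). On these data alone, compound 1 holds a limit and not a number, so this last step gives only a floor and its true size stays open: the limit of > 100000 nM in this assay, at which 1 of the 4 values shown sits.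

What an amine, a carboxylic acid or a longer chain would do in place of methyl on the aromatic carbon remains open, since the exchange shown here covers only chloro and methyl. All the compounds shown also keep the same shared core, so whether a change there would move the number beyond the scatter is unknown as well.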